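This account rests on a few compounds, and the source may have more. Where it says the series, first, only, none or still open, it means among the compounds named here.

For the measured compounds named here, compound 3 `CCc1cccc2c(OC)c(-c3occ(C)c3CBr)ccc12` holds the only number recorded in a functional assay on MDA-MB-231 cells (Homo sapiens) for cytotoxicity, read by MTT assay, with a stated time of 72 h; on this read-out higher numbers stand for an effect only at larger amounts of compound and lower numbers for an effect already at smaller amounts: compound 3 gives 4.6 ug/mL. Compound 1 `CCCOC(=O)c1c(C)coc1-c1ccc2c(CC)cccc2c1OC` gives > 10 ug/mL, which is a limit of the assay rather than a number. Compound 2 `CCc1cccc2c(OC(C)=O)c(-c3occ(C)c3COC(C)=O)ccc12` likewise gives > 10 ug/mL, again a limit. Going by the values given here, the one measured step, an at least 2.1-fold lower number from compound 1 to compound 3 (0.33 log units; beyond the scatter), runs toward the bromomethyl. Compound 4 `CCc1cccc2c(OC)c(-c3occ(C)c3COC(C)=O)ccc12` differs from compound 3 by acetoxy in place of bromo on a saturated chain carbon bound to an aromatic carbon; it carries the acetoxymethyl that compound 2 also bears, and compound 2 sits at the limit of > 10 ug/mL in this assay, at which 2 of the 3 values shown sit. Among the compounds with values here, since the only step moved when the bromomethyl entered, the expected step of a 2.6-fold higher number from compound 3 to compound 4 (0.42 log units; beyond the scatter) is a modest rise back toward that limit. Compound 4 is therefore estimated at 12 ug/mL, within 4 ug/mL to 35 ug/mL.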

Compound 4, concentration for half-maximal effect: 3.5 ug/mL
Compound 4: the middle estimate sits 3.4-fold (0.54 log units) above what was measured; measured number below the stated range.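

In this assay, replacing bromo with acetoxy on this saturated chain carbon gives a 1.3-fold lower number from compound 3 to compound 4 (0.12 log units; within the scatter), so the bromomethyl is not required at this position. The acetoxymethyl does not by itself tie a compound to the limit: methyl in place of acetyl on the oxygen gives an at least 2.8-fold lower number from compound 2 to compound 4 (0.45 log units; beyond the scatter), and acetoxymethyl in place of propoxycarbonyl gives an at least 2.8-fold lower number from compound 1 to compound 4 (0.45 log units; beyond the scatter). Compound 1 and compound 2 remain limits, not numbers: the limit of > 10 ug/mL in this assay, at which 2 of the 4 values shown sit. From the compounds shown here alone, whether an amine or a hydroxyl on this carbon would keep the same level stays open.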